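This account rests on a few compounds, and the source may have more. Where it says the series, first, only, none or still open, it means among the compounds named here.

Working notes on the series. Compound 1 `N#CC1=C(N)Oc2c(c3nc4ccccc4nc3c3ccccc23)C12C(=O)N(Cc1cnnn1-c1ccc(F)cc1)c1ccccc12` and compound 2 `N#CC1=C(N)Oc2c(c3nc4ccccc4nc3c3ccccc23)C12C(=O)N(Cc1cnnn1-c1ccc([N+](=O)[O-])cc1)c1ccccc12` carry the shared core and differ only in the aryl group on an aromatic nitrogen. In a functional assay on HCT-116 cells (Homo sapiens) for antiproliferative activity, read by MTT assay, with a stated time of 48 h (a lower number here means a stronger inhibitor, a higher number a weaker inhibitor), compound 1 gives > 50000 nM, which is a limit of the assay. In this assay compound 2 gives > 50000 nM, also a limit. The step that the two limits leave unreadable from compound 1 to compound 2 therefore cannot be read. In this assay compound 3 `COc1ccccc1-n1nncc1CN1C(=O)C2(C(C#N)=C(N)Oc3c(N)cc4nc5ccccc5nc4c32)c2ccccc21` gives > 50000 nM, again a limit, so compound 3 stands at the same limit as the two others, as the limit of > 50000 nM in this assay, at which 3 of the 3 values shown sit, records. Compound 4 `N#CC1=C(N)Oc2c(N)cc3nc4ccccc4nc3c2C12C(=O)N(Cc1cnnn1-c1c(Cl)cc(Cl)cc1Cl)c1ccccc12` is to be measured in this assay; the change is 2,4,6-trichlorophenyl in place of 2-methoxyphenyl on an aromatic nitrogen. Going by the values given here, the single measured step is unreadable, so no measured step gives a size for this change, and every aryl variant shown sits at the limit. For compound 4 a result at the limit is expected, 50000 nM (range 20000 nM to 200000 nM). The step of a number no higher from compound 3 to compound 4 (the limit leaves the size open) is thus expected to be none beyond the scatter.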

Compound 4, half-maximal inhibitory concentration: 12100 nM
Compound 4: middle estimate off by 4.1-fold (0.62 log units), on the high side; the whole stated range lies above it.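

In this assay, going by these compounds alone, the aryl group on this aromatic nitrogen can bring a compound off the limit, which the earlier compounds did not show: 2,4,6-trichlorophenyl in place of 2-methoxyphenyl gives an at least 4.1-fold lower number from compound 3 to compound 4 (0.61 log units; beyond the scatter). From the compounds shown here alone, the step starts from a limit, so its full size stays open, and the step from fluoro to nitro cannot be read. Compound 4 alone carries a measured number: the limit of > 50000 nM in this assay, at which 3 of the 4 values shown sit.

Open, going by these compounds, is whether a phenyl with a single chlorine, or one bearing an amine, also leaves the limit. Also open, on these data alone, is how 2,4,6-trichlorophenyl behaves on the core of compound 1.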